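Naphthyl triaryl series: Z to E alkene switch

This account rests on a few compounds, and the source may have more. Where it says the series, first, only, none or still open, it means among the compounds named here.

Measured so far:
compound 1 `COc1ccc(C(O)(Cc2ccc(C)cc2)c2cccc3ccccc23)c(OC)c1OC` — 18700 nM
compound 2 `COc1ccc(C(c2ccc(OCCO)cc2)c2cccc3ccccc23)c(OC)c1OC` — > 20000 nM (a limit)
compound 3 `COc1ccc(/C(=C\c2ccc(F)cc2)c2cccc3ccccc23)c(OC)c1OC` — > 20000 nM (a limit)

For the measured compounds named here, in a functional assay on A549 cells (Homo sapiens) for inhibition, read by sulforhodamine B assay, with a stated time of 48 h (on this read-out lower numbers stand for stronger inhibition and higher numbers for weaker inhibition), compound 1 gives 18700 nM, the only numeric value in the set. Compound 2 reaches only a limit of this assay, > 20000 nM. Compound 3 likewise gives only a limit, > 20000 nM. On the numbers shown compound 3 therefore sits at the limit of > 20000 nM in this assay, at which 2 of the 3 values shown sit, and no ranking against compound 1 can be read from it beyond the fact that compound 1 returned a number.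

Compound 4 `COc1ccc(/C(=C/c2ccc(F)cc2)c2cccc3ccccc23)c(OC)c1OC` is the next entry. Relative to compound 3: the two compounds have the same atoms and bonds and differ only in configuration as drawn: 1 of 1 stereo elements differ; a double bond is drawn Z in compound 3 and E in compound 4. Going by the values given here, no step between two measured compounds of this set involves such a change, so no measured size is available as a guide. Because compound 3 is itself a limit, > 20000 nM, only a move to a numeric value in this assay would be detectable for compound 4, and no direction can be anchored in the data; the step from compound 3 to compound 4 is expected to be a step that the limit leaves unreadable from compound 3 to compound 4, that is, none resolvable beyond the scatter. Compound 4 is thus expected to give about 25000 nM in this assay, within 6000 nM to 100000 nM, most probably again as a limit.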

Compound 4, half-maximal inhibitory concentration: 18600 nM
Compound 4: middle estimate off by 1.3-fold (0.13 log units), on the high side, and the stated range covers the measured number.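

In this assay, for the compounds shown here, moving the double bond from Z to E gives the first readable step of the set, an at least 1.0-fold lower number from compound 3 to compound 4 (0.03 log units; that floor lies within the scatter). Going by these compounds, compound 3 is only a limit, > 20000 nM, so the true size of the step stays open, and the printed floor alone does not show a change beyond the scatter. Whatever its size, the step can be assigned to the configuration of this double bond alone, with no other change in the pair: the fact that compounds 3 and 4 differ only in the configuration as drawn.

Open, on these data alone, is whether the same Z to E switch reads alike when the fluorine of compound 3 and compound 4 gives way to an amine or a carboxylic acid. Also open, as far as these compounds go, is whether any change to the shared core moves the number clearly beyond the scatter in this assay.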